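Notes on compounds 2 and 3: a nitrophenyl exchange

This account rests on a few compounds, and the source may have more. Where it says the series, first, only, none or still open, it means among the compounds named here.

For the measured compounds named here, compound 2 `COc1ccc(COc2ccc(OCCOCCNC3CCCC3)cc2)cc1` holds the only measured number in the set. In a functional assay on SK-OV-3 cells (Homo sapiens) for inhibition, read by CCK-8 assay, with a stated time of 70 h (on this read-out lower numbers stand for stronger inhibition and higher numbers for weaker inhibition), compound 2 gives 15700 nM. Compound 1 `c1ccc(COc2ccc(OCCOCCNc3ccccc3)cc2)cc1` is reported in this assay only as a limit, > 100000 nM, and not as a number. Compound 3 `O=[N+]([O-])c1ccccc1COc1ccc(OCCOCCNC2CCCC2)cc1` is not yet measured; it differs from compound 2 by 2-nitrophenyl in place of 4-methoxyphenyl on a saturated chain carbon bound to an oxygen on an aromatic ring. Going by the values given here, no step between measured compounds is available to size this change, so the expected step in this assay is a 1.0-fold lower number from compound 2 to compound 3 (0.02 log units; within the scatter), with no direction beyond the scatter assumed. Compound 3 is accordingly estimated at 15000 nM in this assay, within 4000 nM to 60000 nM.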

Compound 3, half-maximal inhibitory concentration: 5370 nM
For compound 3 the middle estimate is 2.8-fold (0.45 log units) above the measured one; measured number inside the range.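

In this assay, the group on the saturated chain carbon bound to an oxygen on an aromatic ring moves the read-out beyond the scatter: 2-nitrophenyl in place of 4-methoxyphenyl gives a 2.9-fold lower number from compound 2 to compound 3 (0.47 log units; beyond the scatter). This position therefore accepts this exchange without loss, though the step is modest. Nothing shown accounts for this step.

Still open, going by these compounds, is whether the step depends on the nitro group itself or on the loss of the methoxy group. An amine or a nitrile in place of the nitro group on the same ring would help separate the two.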